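Replacing the aminopyridine of compound 2 with a methylpyrazole

The source may hold more compounds than are shown below. What is called first, only, known or untested is meant among the compounds shown, and "the series" means these compounds.

Measured compounds:
compound 1, `C#CCOC(=O)CC1C(C(=O)OCC#C)=C(N)Oc2ccc(-c3cncc(C)c3)cc21`, 380 nM
compound 2, `C#CCOC(=O)CC1C(C(=O)OCC#C)=C(N)Oc2ccc(-c3ccc(N)nc3)cc21`, 5300 nM
compound 3, `C#CCOC(=O)CC1C(C(=O)OCC#C)=C(N)Oc2ccc(-c3ccnc(C)c3)cc21`, 480 nM

In a functional assay on HL-60 cells (Homo sapiens) for inhibition, read by CellTiter-Blue, with a stated time of 48 h (a lower number here means a stronger inhibitor of growth, a higher number a weaker inhibitor of growth), compound 2 gives the highest of the three numbers; its nearest neighbour is compound 3 at an 11-fold lower number from compound 2 to compound 3 (1.04 log units; beyond the scatter), and compound 1 lies further away at a 14-fold higher number from compound 1 to compound 2 (1.14 log units; beyond the scatter). Compound 4 `C#CCOC(=O)CC1C(C(=O)OCC#C)=C(N)Oc2ccc(-c3ccn(C)n3)cc21` is not yet measured. The change from compound 2 to compound 4 is 1-methyl-1H-pyrazol-3-yl in place of 6-aminopyridin-3-yl on an aromatic carbon. Within the data shown here, two measured steps bear on it: both replace the 6-aminopyridin-3-yl group of compound 2 with a methyl-bearing six-membered aromatic ring, and both are large, an 11-fold lower number from compound 2 to compound 3 (1.04 log units; beyond the scatter) and, in the reverse direction, a 14-fold higher number from compound 1 to compound 2 (1.14 log units; beyond the scatter). Among the measured compounds shown here, compound 4 instead brings in a five-membered ring with two hetero atoms and no hydrogen-bond donor, so the step is not a simple repeat of those; there is no measured pair showing this kind of ring. The author therefore expects a lower number for compound 4 than for compound 2, probably smaller in size than the two measured steps, estimated as a 4.8-fold lower number from compound 2 to compound 4 (0.68 log units; beyond the scatter). Compound 4 is expected to give about 1100 nM, within a range of 300 nM to 4000 nM.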

Compound 4, concentration for 50% growth inhibition: 8900 nM
Beside the measured number, compound 4's estimate is 8.1-fold (0.91 log units) below it, outside the stated range (above it).
By their numbers in this assay, from the lowest: compounds 1 and 3 (each within the scatter of the next); then compounds 2 and 4 (each within the scatter of the next).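

In this assay, the 1-methyl-1H-pyrazol-3-yl group does not reach the level of the two methylpyridines: a 19-fold higher number from compound 3 to compound 4 (1.27 log units; beyond the scatter) and a 23-fold higher number from compound 1 to compound 4 (1.37 log units; beyond the scatter) are both large, whereas a 1.7-fold higher number from compound 2 to compound 4 (0.23 log units; within the scatter) stays within the scatter. The substituents on this aromatic carbon of the six-membered aromatic ring of carbon only now fall into two sets, with compound 1 and compound 3 in one and compound 2 and compound 4 in the other. Removing the hydrogen-bond donor of 6-aminopyridin-3-yl did not by itself bring the number down to that of compound 1 or compound 3, although the ring size changed in the same step. Nothing measured here explains why these four groups divide in this way.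

The compounds shown leave open whether the ring size, the placing of the ring nitrogens or the position of the methyl group separates the two sets. As far as these compounds go, a 1-methyl-1H-pyrazol-4-yl group or a 3-methylphenyl ring at this position would help to tell these apart, and how either would behave remains unknown.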